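Moving the Trifluoromethyl Group Around the Outer Phenyl Ring

The source may report more compounds than this note shows. Statements on the series, on what has been measured and on what is new or still open speak of the compounds shown alone.

Among the three measured compounds, compound 3 `Oc1ccccc1-c1cc(-c2ccccc2C(F)(F)F)cc(-c2ccccc2O)n1` is the only one that gives a number at all in a functional assay on T47D cells (Homo sapiens) for inhibition; on this read-out higher numbers stand for weaker inhibition and lower numbers for stronger inhibition: compound 3 gives 22500 nM. Compound 1 `Oc1ccccc1-c1cc(-c2ccccc2F)cc(-c2ccccc2O)n1` gives > 50000 nM in this assay, which is a limit of the assay rather than a number (the limit of > 50000 nM in this assay, at which 2 of the 3 values shown sit). Compound 2 `Oc1ccccc1-c1cc(-c2ccc(F)cc2)cc(-c2ccccc2O)n1` likewise gives > 50000 nM, again a limit. The steps recorded are an at least 2.2-fold lower number from compound 1 to compound 3 (0.34 log units; beyond the scatter) and an at least 2.2-fold lower number from compound 2 to compound 3 (0.34 log units; beyond the scatter), while the step from compound 1 to compound 2 is a step that the two limits leave unreadable from compound 1 to compound 2, so the effect of merely moving a fluoro group to another carbon of the same phenyl ring cannot be read.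

Compound 4 `Oc1ccccc1-c1cc(-c2cccc(C(F)(F)F)c2)cc(-c2ccccc2O)n1` keeps the same atoms as compound 3 but joins them differently: 3-(trifluoromethyl)phenyl in place of 2-(trifluoromethyl)phenyl on an aromatic carbon. For the measured compounds named here, no measured pair shows a trifluoromethyl group relocated on that ring; the nearest comparison, compound 1 against compound 2, is unreadable because of the two limits. The only secure point is that compound 3 lies not far from the limit itself. Compound 4 is therefore expected to give a weak value, estimated at 35000 nM, with a range from 12000 nM to 100000 nM. That estimate means a step of a 1.6-fold higher number from compound 3 to compound 4 (0.19 log units; within the scatter) from compound 3, and it is expected that compound 4 may well return only a limit.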

Compound 4, half-maximal inhibitory concentration: > 50000 nM
Compound 4: no number, only a limit (the forecaster's own chance of this, stated with the estimate: 40%); middle value at least 1.4-fold (0.15 log units) from the limit.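

For the compounds shown here, exchanging 2-(trifluoromethyl)phenyl for 3-(trifluoromethyl)phenyl, with the same atoms joined differently, gives in this assay an at least 2.2-fold higher number from compound 3 to compound 4 (0.34 log units; beyond the scatter), the first readable change in the place of a group on this outer phenyl ring. Among the compounds shown, the trifluoromethyl group alone therefore does not secure a measurable value, since compound 4 carries it and stops at a limit of the assay, and only compound 3 returns a number; compound 1, with 2-fluorophenyl, also stays at a limit, so this is no general rule for groups at that place on the ring. The steps from compound 1 and from compound 2 to compound 4 cannot be read, as both ends of each are limits: the limit of > 50000 nM in this assay, at which 3 of the 4 values shown sit.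

As far as these compounds go, how far compound 4 lies beyond its limit stays open, so the full size of the loss from moving the trifluoromethyl group is unknown. Also open, from the compounds shown here alone, is whether an amine or a carboxylic acid on this outer phenyl ring would return a number in this assay, and how such a value would compare with that of compound 3.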